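Series notes: carboxymethoxy to isopropoxy on the aromatic oxygen

The source may hold more compounds than are shown below. What is called first, only, known or untested is meant among the compounds shown, and "the series" means these compounds.

Measured so far:
compound 1, `CCOC(=O)COc1ccc2c(=O)c(-c3ccc(O)cc3)coc2c1`, 130 nM
compound 2, `O=C(O)COc1ccc2c(=O)c(-c3ccc(O)cc3)coc2c1`, 1200 nM

Among the compounds with values here, in an assay (Cricetulus griseus) for inhibition of aldehyde dehydrogenase, mitochondrial (Homo sapiens) (a higher number here means a weaker inhibitor, a lower number a stronger inhibitor), compound 2 gives 1200 nM, the highest of the two numbers; its only neighbour is compound 1 at 130 nM, and the measured step reads a 9.2-fold higher number from compound 1 to compound 2 (0.97 log units; beyond the scatter). Compound 3 `CC(C)Oc1ccc2c(=O)c(-c3ccc(O)cc3)coc2c1` is not yet measured; it differs from compound 2 by isopropyl in place of carboxymethyl on an oxygen on an aromatic ring. That single step bears on it only indirectly: it shows the free acid of compound 2 carrying the higher number, so removing the carboxymethyl is expected to lower the number, roughly back toward the level of compound 1. For compound 3 the expected step is a 6.0-fold lower number from compound 2 to compound 3 (0.78 log units; beyond the scatter). Compound 3 is estimated at 200 nM, within 60 nM to 800 nM.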

Compound 3, half-maximal inhibitory concentration: 80 nM
Estimate against measurement, compound 3: 2.5-fold (0.40 log units) above, and the stated range covers the measured number.
By their numbers in this assay, from the lowest: compounds 3 and 1 (each within the scatter of the next); then compound 2.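

On the oxygen on an aromatic ring, the higher number of compound 2 in this assay does not carry over to a simple isopropyl: the change shows a 15-fold lower number from compound 2 to compound 3 (1.18 log units; beyond the scatter) and places the free acid apart from the other two compounds. The ester group is not required to hold that level, as the change shows a 1.6-fold lower number from compound 1 to compound 3 (0.21 log units; within the scatter) without a real separation. Nothing available explains either step.
From the compounds shown here alone, whether methyl, a straight propyl chain or an amine-bearing chain on this oxygen would hold the same level remains open. So does whether the branching of isopropyl matters.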